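The source may report more compounds than this note shows. Statements on the series, on what has been measured and on what is new or still open speak of the compounds shown alone.

Compound 2, `CCCCn1cnc2c(SC(C)C)nc(N)nc21`, gives 120000 nM in an assay on isolated protein for binding affinity to Equilibrative nucleoside transporter 1 (Homo sapiens) (on this read-out lower numbers stand for stronger inhibition and higher numbers for weaker inhibition), the highest of the three numbers seen here. Among the measured compounds shown here, compound 1, `O=[N+]([O-])c1ccc2c(c1)CN(c1ncnc3c1ncn3[C@@H]1O[C@H](CO)[C@@H](O)[C@H]1O)CC2`, gives 5.5 nM in this assay, and compound 3, `CCCCn1cnc2c(SCc3ccccn3)nc(N)nc21`, gives 52500 nM; the step of a 2.3-fold lower number from compound 2 to compound 3 (0.36 log units; beyond the scatter) is the only single change recorded, and it touches the sulfur substituent, not the chain. Compound 4, `CCCn1cnc2c(SC(C)C)nc(N)nc21`, differs from compound 2 by hydrogen in place of methyl on a saturated chain carbon, three bonds along the chain from an aromatic nitrogen. For the measured compounds named here, no recorded step tests a change of this kind, so there is nothing to say it should move the number beyond the scatter in either direction. Compound 4 is therefore expected to give about 140000 nM in this assay, between 50000 nM and 400000 nM, a step of a 1.2-fold higher number from compound 2 to compound 4 (0.07 log units; within the scatter) that is expected to stay within the scatter.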

Compound 4, half-maximal inhibitory concentration: 145000 nM
Compound 4: middle estimate off by 1.0-fold (0.02 log units), on the low side; the range from low to high includes it.
By their numbers in this assay, from the lowest: compound 1; then compound 3; then compounds 2 and 4 (each within the scatter of the next).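

Among the compounds shown here, the change of butyl to propyl gives a 1.2-fold higher number from compound 2 to compound 4 (0.08 log units; within the scatter) in this assay, the first step here that touches the chain rather than the sulfur substituent. At this place, then, the loss of the methyl leaves the number unchanged within the scatter, so the chain length can differ by this much with no readable effect. No measured evidence bears on this result. The compounds shown leave open whether a longer chain, or an amine or carboxylic acid at the chain end, would move the number. They also leave open whether butyl to propyl would read the same with the (pyridin-2-yl)methyl group of compound 3 on the sulfur.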